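Methyl in place of ring hydrogen: outlook for compound 3

A few compounds are considered here, and "the series" means these few. Any claim that something is new, unique, unknown or untested is made for them only; others in the source may bear on it.

Measured so far:
compound 1, `CC(C)OC(=O)N1CCC(Oc2ncnc3c2CCN3c2ccc(S(C)(=O)=O)cc2)CC1`: 126 nM
compound 2, `CS(=O)(=O)c1ccc(N2CCc3c(OC4CCN(C5=NCCCN5)CC4)ncnc32)c(F)c1`: 2000 nM

Both numbers come from a functional assay on CHO-K1 cells for agonist activity at Glucose-dependent insulinotropic receptor (Homo sapiens), read by a luciferase reporter, with a stated time of 5 h; a lower number here means that less compound is needed, a higher number that more compound is needed for the effect. Compound 1 holds the lower of the two; compound 2 lies higher by a margin beyond the scatter. The two structures differ in more than one place, so the gap says nothing beyond the two values themselves.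

Compound 3, `Cc1cc(S(C)(=O)=O)ccc1N1CCc2c(OC3CCN(C(=O)OC(C)C)CC3)ncnc21`, keeps the carbamate end and the core of compound 1 and differs in one place only: methyl in place of hydrogen on an aromatic carbon. For the measured compounds named here, no single-change step between measured compounds is available to lean on, so the step in this assay from compound 1 to compound 3 is expected to be small, within or close to the scatter, with no firm direction. For compound 3 the expected value is 150 nM, within 40 nM to 600 nM, which means an expected step of a 1.2-fold higher number from compound 1 to compound 3 (0.08 log units; within the scatter).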

Compound 3, half-maximal effective concentration: 100 nM
Estimate against measurement, compound 3: 1.5-fold (0.18 log units) above; low and high end bracket the measured number.
By their numbers in this assay, from the lowest: compounds 3 and 1 (each within the scatter of the next); then compound 2.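

In this assay, methyl in place of hydrogen on an aromatic carbon, ortho to a large group and meta to a methylsulfonyl group, gives a 1.3-fold lower number from compound 1 to compound 3 (0.10 log units; within the scatter), with the carbamate end and the core of compound 1 unchanged. For the compounds shown here, this is the first single-change reading: the 2-methyl-4-(methylsulfonyl)phenyl group of compound 3 holds the value of the 4-(methylsulfonyl)phenyl group of compound 1 within the scatter. No measurement at hand accounts for this result.

Going by these compounds alone, whether this place also accepts an ethyl, a methoxy or an amine remains open, since methyl is the only group read there in a single-change step. From the compounds shown here alone, it is also open whether the same methyl would give a similar step with another group in place of the carbamate end.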